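This account rests on a few compounds, and the source may have more. Where it says the series, first, only, none or still open, it means among the compounds named here.

In a functional assay on A549 cells (Homo sapiens) for antiproliferative activity, read by MTT assay, with a stated time of 72 h (on this read-out lower numbers stand for stronger inhibition and higher numbers for weaker inhibition), compound 1 `O=C(Nc1ccccc1)C(Cl)Cl` gives 130000 nM, compound 2 `Cc1cccc(NC(=O)C(Cl)Cl)c1` gives 41100 nM, and compound 3 `O=C(Nc1cccc(Cl)c1)C(Cl)Cl` gives 14800 nM, the lowest number of the three: there is a 2.8-fold lower number from compound 2 to compound 3 (0.44 log units; beyond the scatter) and an 8.8-fold lower number from compound 1 to compound 3 (0.94 log units; beyond the scatter). Compound 4 `O=C(Nc1cccc(Br)c1)C(Cl)Cl` differs from compound 3 by bromo in place of chloro on an aromatic carbon. Going by the values given here, no measured pair exchanges one halogen for another, so the nearest guides are an 8.8-fold lower number from compound 1 to compound 3 (0.94 log units; beyond the scatter) and a 2.8-fold lower number from compound 2 to compound 3 (0.44 log units; beyond the scatter), both of which place the chloro-bearing compound 3 at the low end. Exchanging chloro for bromo is a smaller alteration than either of those, so the expected step is a 1.5-fold lower number from compound 3 to compound 4 (0.17 log units; within the scatter), small and possibly not beyond the scatter. Compound 4 is therefore estimated at 10000 nM in this assay, within a range from 4000 nM to 30000 nM.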

Compound 4, half-maximal inhibitory concentration: 7800 nM
Compound 4: the middle estimate sits 1.3-fold (0.11 log units) above what was measured; the range from low to high includes it.
By their numbers in this assay, from the lowest: compounds 4 and 3 (each within the scatter of the next); then compound 2; then compound 1.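

Exchanging one halogen for the other on this aromatic carbon gives a 1.9-fold lower number from compound 3 to compound 4 (0.28 log units; within the scatter) so on these numbers chloro and bromo cannot be told apart. Bromo nevertheless stands clear of the other two groups at this place, with a 5.3-fold lower number from compound 2 to compound 4 (0.72 log units; beyond the scatter) when it replaces methyl and a 17-fold lower number from compound 1 to compound 4 (1.22 log units; beyond the scatter) when it replaces hydrogen, the largest step in the set. No measurement here explains these steps.

As far as these compounds go, whether iodo, a methoxy group or an amine at this place would match the halogens remains open. So does whether bromo would act alike on another carbon of the ring.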